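Exchanging the dioxin ring for a methoxyphenyl on the amine

The source may report more compounds than this note shows. Statements on the series, on what has been measured and on what is new or still open speak of the compounds shown alone.

Compound 3 `O=S(=O)(NCCCNCC1COc2ccccc2O1)c1cc(C(F)(F)F)cc(C(F)(F)F)c1` gives 1500 nM in a functional assay on A2780 cells (Homo sapiens) for inhibition, read by MTT assay, with a stated time of 72 h (on this read-out lower numbers stand for stronger inhibition of growth and higher numbers for weaker inhibition of growth), the lowest of the three numbers shown, although compound 2 `COc1cccc(CNCCCNS(=O)(=O)c2cc(C(F)(F)F)cc(C(F)(F)F)c2)c1` with 1600 nM and compound 1 `O=S(=O)(NCCCCNCc1ccc(Br)cc1)c1cc(C(F)(F)F)cc(C(F)(F)F)c1` with 2100 nM both lie within the scatter of it. The two measured steps, a 1.3-fold lower number from compound 1 to compound 2 (0.12 log units; within the scatter) and a 1.1-fold lower number from compound 2 to compound 3 (0.03 log units; within the scatter), varied the group on the saturated chain carbon bound to the amine nitrogen without moving this assay beyond the scatter. Compound 4 `COc1ccccc1CNCCCNS(=O)(=O)c1cc(C(F)(F)F)cc(C(F)(F)F)c1` makes the change (2-methoxyphenyl in place of 2,3-dihydro-1,4-benzodioxin-2-yl on a saturated chain carbon bound to an amine nitrogen). For the measured compounds named here, the closest precedent is the step from compound 2 to compound 3, which replaced 3-methoxyphenyl with 2,3-dihydro-1,4-benzodioxin-2-yl; compound 4 brings back a methoxyphenyl. One therefore expects a 1.1-fold higher number from compound 3 to compound 4 (0.03 log units; within the scatter) to remain within the scatter, and estimates for compound 4 1600 nM with a range of 700 nM to 3600 nM.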

Compound 4, concentration for 50% growth inhibition: 1500 nM
For compound 4 the middle estimate is 1.1-fold (0.03 log units) above the measured one; measured number inside the range.
By their numbers in this assay, from the lowest: compounds 3, 4, 2 and 1 (each within the scatter of the next).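

In this assay the exchange gave no change at the digits printed from compound 3 to compound 4 (within the scatter), so on a saturated chain carbon bound to an amine nitrogen the non-aromatic ring of 2,3-dihydro-1,4-benzodioxin-2-yl can give way to 2-methoxyphenyl without a shift beyond the scatter. Exchanging 3-methoxyphenyl for 2-methoxyphenyl also stays inside it, with a 1.1-fold lower number from compound 2 to compound 4 (0.03 log units; within the scatter), and so does the wider change, with a 1.4-fold lower number from compound 1 to compound 4 (0.15 log units; within the scatter). Going by these compounds, whether a carboxylic acid or a primary amine on this group would move the number beyond the scatter stays open. No supporting data explain why these groups read alike.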